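This account rests on a few compounds, and the source may have more. Where it says the series, first, only, none or still open, it means among the compounds named here.

Three compounds have so far been measured in a functional assay on ECa-109 cells for inhibition, with ECa-109 cell line (Homo sapiens) as the target, read by sulforhodamine B assay; on this read-out lower numbers stand for stronger inhibition and higher numbers for weaker inhibition:

Compound 1 `O=C1C(Nc2ccccc2)=CC(=O)c2c1nc1n2[C@H]2OC[C@@H](O)[C@H]2OC1`: 3560 nM
Compound 2 `O=C1C=C(Nc2ccc(Br)cc2)C(=O)c2c1nc1n2[C@H]2OC[C@@H](O)[C@H]2OC1`: 2850 nM
Compound 3 `O=C1C=C(Nc2cccc(Cl)c2)C(=O)c2c1nc1n2[C@H]2OC[C@@H](O)[C@H]2OC1`: 4690 nM

All three numbers lie within the usual scatter of one another, and compound 1 sits among them without standing apart. Within the data shown here, the one step measured so far, a 1.6-fold higher number from compound 2 to compound 3 (0.22 log units; within the scatter), exchanges one substituted phenyl ring for another on the anilino nitrogen and stays within the scatter. Compound 4 `CCCN(CCC)C1=CC(=O)c2c(nc3n2[C@H]2OC[C@@H](O)[C@H]2OC3)C1=O` differs from compound 1 by dipropylamino in place of anilino on a double-bonded ring carbon. Among the measured compounds shown here, no measured step removes the aromatic ring in this way, so the earlier step gives only weak guidance, and no change beyond the scatter is expected. Compound 4 is therefore estimated at 4500 nM, between 1200 nM and 17000 nM, a step of a 1.3-fold higher number from compound 1 to compound 4 (0.10 log units; within the scatter).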

Compound 4, half-maximal inhibitory concentration: > 16000 nM
Compound 4: no number, only a limit; the forecaster's own chance of this, stated with the estimate: 15%; middle value at least 3.5-fold (0.55 log units) from the limit.
By their numbers in this assay, from the lowest: compounds 2, 1 and 3 (each within the scatter of the next). At a limit, above all of these: compound 4.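

Changes on the phenyl ring had stayed within the scatter, but replacing the whole anilino group shows that this ring carbon does not accept every amine: in this assay, the change gives an at least 4.4-fold higher number from compound 1 to compound 4 (0.65 log units; beyond the scatter). The heavy-atom count stays the same, while the aromatic ring and the hydrogen-bond donor both leave. Compound 4 gives only a limit, not a number: the limit of > 16000 nM in this assay, at which 1 of the 4 values shown sits.

The compounds shown leave open whether the ring or the donor matters. A propylamino group, which keeps the donor without the ring, and a methylanilino group, which keeps the ring without the donor, would separate the two.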